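A few compounds are considered here, and "the series" means these few. Any claim that something is new, unique, unknown or untested is made for them only; others in the source may bear on it.

Within the data shown here, in an ADME assay on microsomes from liver (Rattus norvegicus) for metabolic stability, read by LC-MS, using NADPH, at 37 degrees C (a lower number here means that the compound disappears faster, a higher number that the compound lasts longer), compound 2 `Cc1oc(-c2c(Cl)cccc2Br)nc1CN1CCC(C(=O)NCCCN2C[C@H](C)C[C@H](C)C2)CC1` gives 0.0233 h and holds the lower of the two numbers so far, while compound 1 `Cc1oc(-c2c(Cl)cccc2Cl)nc1CN1CCC(C(=O)NCCCN2C[C@H](C)C[C@H](C)C2)CC1` gives 0.0483 h as its measured value. Compound 3 `COc1cccc(Br)c1-c1nc(CN2CCC(C(=O)NCCCN3C[C@H](C)C[C@H](C)C3)CC2)c(C)o1` carries methoxy in place of chloro on an aromatic carbon. Among the measured compounds shown here, the only measured step (a 2.1-fold lower number from compound 1 to compound 2 (0.32 log units; beyond the scatter)) was modest and put bromo in place of chloro, so it says little about methoxy, which no measured compound carries. No direction can be drawn from this, and the expected step (a 1.2-fold lower number from compound 2 to compound 3 (0.07 log units; within the scatter)) stays within the scatter. For compound 3 the estimated half-life is 0.02 h (range 0.008 h to 0.05 h).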

Compound 3, half-life: 0.0583 h
Compound 3: middle estimate off by 2.9-fold (0.46 log units), on the low side; the measured number lies above the stated range.
By their numbers in this assay, from the lowest: compound 2; then compounds 1 and 3 (each within the scatter of the next).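

In this assay, methoxy in place of chloro gives a 2.5-fold higher number from compound 2 to compound 3 (0.40 log units; beyond the scatter), whereas the earlier bromo for chloro change lowered the number, so changes on this aromatic ring can move the half-life either way. Against the 2,6-dichlorophenyl compound, the 2-bromo-6-methoxyphenyl group gives a 1.2-fold higher number from compound 1 to compound 3 (0.08 log units; within the scatter), which leaves that pair level. No available evidence explains the rise. Going by these compounds, whether a larger alkoxy group such as ethoxy would follow methoxy remains open. So does the outcome with fluoro or an amine at this place.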